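The source may hold more compounds than are shown below. What is called first, only, known or untested is meant among the compounds shown, and "the series" means these compounds.

Three compounds with a shared core have numbers in an ADME assay on a cell-free system (plasma, Homo sapiens) for protein binding, read by HPLC. Compound 1 (`COc1cc(-c2cc(-c3ccc(S(C)(=O)=O)cc3)cnc2N)ccc1O`) gives 82.8%, compound 2 (`COc1ccc(-c2cc(-c3ccc(S(C)(=O)=O)cc3)cnc2N)cn1`) gives 90% and compound 3 (`Cc1ccc(-c2cc(-c3ccc(S(C)(=O)=O)cc3)cnc2N)cn1`) gives 74.4%. Compound 3 thus lies within the usual scatter of compound 1 and clearly apart from compound 2.

Compound 4 (`CS(=O)(=O)c1ccc(-c2cnc(N)c(-c3ccc(CO)nc3)c2)cc1`) alters compound 3 in one place: hydroxy in place of hydrogen on a saturated chain carbon bound to an aromatic carbon. Methyl becomes hydroxymethyl, so 6-methylpyridin-3-yl turns into 6-(hydroxymethyl)pyridin-3-yl.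

The closest measured step is a 2.6-fold higher unbound fraction from compound 2 to compound 3 (0.41 log units; beyond the scatter), with methyl in place of methoxy on an aromatic carbon. It shows that a modest move beyond the scatter is possible when this group is changed. Going by the values given here, it is a different change, however, and no measured pair adds hydroxy to a saturated chain carbon, so its size is only a rough guide and its direction does not carry over.

The expected change is a 1.4-fold higher unbound fraction from compound 3 to compound 4 (0.14 log units; within the scatter), an estimate that stays within the scatter and leans tentatively towards more free compound. For compound 4 the estimated value is 65%, with an expected range from 45% to 82%.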

Compound 4, plasma protein binding: 45.9%
Compound 4: the middle estimate sits 1.5-fold (0.19 log units) (unbound fraction) below what was measured; measured number inside the range.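

In this assay, adding hydroxy to a saturated chain carbon bound to an aromatic carbon gives a 2.1-fold higher unbound fraction from compound 3 to compound 4 (0.32 log units; beyond the scatter), so even this single added oxygen moves the result beyond the scatter, towards more free compound. Seen from the other side, hydroxymethyl in place of methoxy on an aromatic carbon gives a 5.4-fold higher unbound fraction from compound 2 to compound 4 (0.73 log units; beyond the scatter), the widest step printed for this group of compounds. Nothing measured here explains why binding to plasma protein shifts with this change.

On these data alone, how an amine, a carboxylic acid or a longer chain at this place would compare with hydroxymethyl stays open. So does whether adding hydroxy would give a step of similar size on a different core, since only one such pair is shown.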